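A few compounds are considered here, and "the series" means these few. Any claim that something is new, unique, unknown or untested is made for them only; others in the source may bear on it.

Working notes on the series, toxicity read-out.

Three compounds have numbers in a toxicity assay on MT4 cells (Homo sapiens) for cytotoxicity, read by MTT assay, with a stated time of 5 days; on this read-out lower numbers stand for higher toxicity in this test and higher numbers for lower toxicity in this test. Compound 1 `Cc1cnc(Nc2ccc(C#N)cc2)nc1Nc1c(F)cc(-c2ccnc(F)c2)cc1F` gives 167000 nM in this assay. Going by the values given here, compound 2 `Cc1cnc(Nc2ccc(C#N)cc2)nc1Nc1c(F)cc(-c2ccc(C#N)nc2)cc1F` gives 62000 nM in this assay, and the one measured single-point step, a 2.7-fold lower number from compound 1 to compound 2 (0.43 log units; beyond the scatter), is an exchange of one aromatic ring for another on the core of compound 1. Compound 3 `Cc1ccc(-c2cc(C)c(Nc3ccnc(Nc4ccc(C#N)cc4)n3)c(C)c2)s1` gives 28000 nM in this assay, the lowest of the three numbers; compound 2 stands nearest to it and compound 1 furthest, both beyond the scatter, so compound 3 is the most toxic of the measured set.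

Compound 4 `Cc1cc(-c2cnc(C(F)(F)F)nc2)cc(C)c1Nc1ccnc(Nc2ccc(C#N)cc2)n1` differs from compound 3 by 2-(trifluoromethyl)pyrimidin-5-yl in place of 5-methylthiophen-2-yl on an aromatic carbon. Among the compounds with values here, the only step that bears on this is a 2.7-fold lower number from compound 1 to compound 2 (0.43 log units; beyond the scatter): a ring-for-ring exchange, though on a different core, at a different place and with different rings entering and leaving, so its size is a loose guide at best. Two aromatic-ring swaps on one core are not enough to set a direction for a third on another. The expectation is therefore a step of no more than modest size in this assay, with no clear direction, and the estimated step of a 1.3-fold higher number from compound 3 to compound 4 (0.10 log units; within the scatter) reflects that. Compound 4 is expected to give about 35000 nM in this assay, within a range of 12000 nM to 100000 nM.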

Compound 4, half-maximal cytotoxic concentration: 4900 nM
For compound 4 the middle estimate is 7.1-fold (0.85 log units) above the measured one; measured number outside the range, below it.
By their numbers in this assay, from the lowest: compound 4; then compound 3; then compound 2; then compound 1.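

On the core of compound 3, at the aromatic carbon meta to two methyl groups and para to a large group, 2-(trifluoromethyl)pyrimidin-5-yl in place of 5-methylthiophen-2-yl gives a 5.7-fold lower number from compound 3 to compound 4 (0.76 log units; beyond the scatter) in this assay, so the read-out at this position responds to a ring-for-ring exchange, here towards higher toxicity in this test. Together with a 2.7-fold lower number from compound 1 to compound 2 (0.43 log units; beyond the scatter), this makes two ring exchanges that lower the number, but they sit on different cores and involve different rings, so they establish no general rule. The new step also combines several changes, as a five-membered ring with one hetero atom gives way to a six-membered ring with two, which also carries a trifluoromethyl group, and no measurement at hand accounts for the step.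

The compounds shown leave open whether the step follows the ring itself or the trifluoromethyl group on it. From the compounds shown here alone, how a plain phenyl ring, an amine or a carboxylic acid at this position would read in this assay also remains open.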